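Swapping Bromine for Chlorine in a Thiourea Analogue

The compounds below may be only part of what the source reports. "The series", "measured", "known", "first", "only" and "open" are said of these compounds alone.

Of the compounds shown here, three have been tested in a functional assay on U-373MG ATCC cells (Homo sapiens) for inhibition, read by MTT assay, with a stated time of 72 h; a lower number here means a stronger inhibitor, a higher number a weaker inhibitor. Compound 1 `CC1(C)CC(NC(=O)Nc2ccccc2Cl)c2cc(Cl)ccc2O1` gives 17000 nM in this assay, and compound 2 `CC1(C)CC(NC(=O)Nc2ccccc2Cl)c2cc(Br)ccc2O1` gives 19000 nM. These two share a core and differ in one spot: chloro in place of bromo on an aromatic carbon. In this assay this gives a 1.1-fold lower number from compound 2 to compound 1 (0.05 log units; within the scatter), so the swap leaves the result essentially unchanged. Compound 3 `CC1(C)CC(NC(=S)NCc2ccccc2)c2cc(Br)ccc2O1` differs from compound 2 in more than one place; how the two cores differ is not broken down here. In this assay compound 3 gives 29000 nM, a number within the scatter of the other two.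

Compound 4 `CC1(C)CC(NC(=S)NCc2ccccc2)c2cc(Cl)ccc2O1` has not yet been measured. It arises from compound 3 by the same change that turns compound 2 into compound 1: chloro in place of bromo on an aromatic carbon. That change, applied to compounds 2 and 1, produced only a 1.1-fold lower number from compound 2 to compound 1 (0.05 log units; within the scatter). For compound 4 the expected step in this assay is accordingly a 1.1-fold lower number from compound 3 to compound 4 (0.03 log units; within the scatter), resting on that single measured pair and therefore held loosely. Compound 4 is estimated to give 27000 nM in this assay, with a plausible range from 12000 nM to 60000 nM.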

Compound 4, half-maximal inhibitory concentration: 64000 nM
For compound 4 the middle estimate is 2.4-fold (0.37 log units) below the measured one; the measured number lies above the stated range.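

In this assay, putting chloro in place of bromo on an aromatic carbon gives a 2.2-fold higher number from compound 3 to compound 4 (0.34 log units; beyond the scatter), a modest step that lies beyond the usual scatter, whereas the same change between compound 2 and compound 1 stayed within it. Set side by side, however, the two steps cannot be told apart: the same change on two cores in this assay, a 1.1-fold lower number (0.05 log units; within the scatter) from compound 2 to compound 1 and a 2.2-fold higher number (0.34 log units; beyond the scatter) from compound 3 to compound 4, 2.5-fold (0.39 log units) apart, within the scatter of two such steps. This does not show that the change acts differently on the two cores, nor does it prove that it acts the same, so two pairs give only a rough guide for carrying the change from one core to the other.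

Still open, going by these compounds, is how other groups on that aromatic carbon would read, such as fluoro, methoxy or an amine, as only bromo and chloro appear there. Also open, on these data alone, is how a urea carrying the benzyl group, or a thiourea carrying the chlorophenyl group, would read, as such compounds would separate the effect of the linking group from that of the group at its end.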